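Bromo in Place of Hydroxy on the Benzoyl Ring

The source may report more compounds than this note shows. Statements on the series, on what has been measured and on what is new or still open speak of the compounds shown alone.

Measured compounds:
compound 1 `O=C(NNc1nc2ccccc2nc1Cc1ccccc1)c1ccccc1`, 78 nM
compound 2 `O=C(NNc1nc2ccccc2nc1Cc1ccccc1)c1ccc(Cl)cc1`, 34 nM
compound 3 `O=C(NNc1nc2ccccc2nc1Cc1ccccc1)c1ccc(O)cc1`, 1.7 nM

All three share one core and differ only on the benzoyl ring. In an assay for inhibition of Amine oxidase [flavin-containing] A (Bos taurus), read by fluorescence, with a stated time of 60 min (on this read-out lower numbers stand for stronger inhibition and higher numbers for weaker inhibition), compound 3 stands lowest of the three: a 20-fold lower number from compound 2 to compound 3 (1.30 log units; beyond the scatter) and a 46-fold lower number from compound 1 to compound 3 (1.66 log units; beyond the scatter), both beyond the scatter. Compound 4 `O=C(NNc1nc2ccccc2nc1Cc1ccccc1)c1ccc(Br)cc1` carries bromo in place of hydroxy on an aromatic carbon. Among the compounds with values here, no measured step exchanges hydroxy for a halogen directly, but a 2.3-fold lower number from compound 1 to compound 2 (0.36 log units; beyond the scatter) shows what a halogen in that place does, and a 20-fold lower number from compound 2 to compound 3 (1.30 log units; beyond the scatter) shows how much further hydroxy reaches. Bromo, like chloro, brings no hydrogen-bond donor or acceptor, so the number for compound 4 is expected to sit close to that of compound 2. The expected step is an 18-fold higher number from compound 3 to compound 4 (1.25 log units; beyond the scatter). Compound 4 is estimated at 30 nM, expected to fall between 12 nM and 75 nM.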

Compound 4, half-maximal inhibitory concentration: 74 nM
The estimate for compound 4 lay 2.5-fold (0.39 log units) below the measured number, within the range that was stated.
By their numbers in this assay, from the lowest: compound 3; then compound 2; then compounds 4 and 1 (each within the scatter of the next).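

In this assay, a halogen on this aromatic carbon does not by itself give a lower number: bromo in place of hydrogen gives a 1.1-fold lower number from compound 1 to compound 4 (0.02 log units; within the scatter), while bromo in place of chloro gives a 2.2-fold higher number from compound 2 to compound 4 (0.34 log units; beyond the scatter), so the two halogens do not read alike here. Bromo in place of hydroxy gives a 44-fold higher number from compound 3 to compound 4 (1.64 log units; beyond the scatter), which leaves hydroxy as the only group among those shown with a large step from hydrogen. No evidence is available to explain these differences. The compounds shown leave open whether an amine or a methoxy group on this carbon would give a step like that of hydroxy.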